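The source may hold more compounds than are shown below. What is called first, only, known or untested is meant among the compounds shown, and "the series" means these compounds.

Measured so far:
compound 1, `O=C1/C(=C/c2ccccc2)CCC/C1=C\c1ccccc1[N+](=O)[O-]`, 16000 nM
compound 2, `O=C1/C(=C/c2ccc(F)cc2)CCC/C1=C\c1ccccc1[N+](=O)[O-]`, 11000 nM
compound 3, `O=C1/C(=C/c2ccccc2)CCC/C1=C\c1ccc([N+](=O)[O-])cc1`, 123000 nM

All three values come from an ADME assay on HPC cells (Homo sapiens) for cytotoxicity, with a stated time of 24 h; a higher number here means that more compound is tolerated, a lower number that less compound is tolerated. Compound 1 and compound 2 differ by one change, (fluoro in place of hydrogen on an aromatic carbon), and this gave a 1.5-fold lower number from compound 1 to compound 2 (0.16 log units; within the scatter). Compound 3 carries the same atoms as compound 1 joined differently; the difference between the two cores is not broken down here. Compound 3 sits highest of the three, and its gaps to compound 1 and to compound 2 are both beyond the scatter.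

Not yet measured is compound 4, `O=C1/C(=C/c2ccc(F)cc2)CCC/C1=C\c1ccc([N+](=O)[O-])cc1`. It differs from compound 3 by fluoro in place of hydrogen on an aromatic carbon, the same change as that from compound 1 to compound 2, at the same kind of place. Because that earlier step was a 1.5-fold lower number from compound 1 to compound 2 (0.16 log units; within the scatter), a step of similar size is expected here, namely a 1.2-fold lower number from compound 3 to compound 4 (0.09 log units; within the scatter). This rests on a single pair only. For compound 4 the expected value in this assay is 100000 nM, with a likely range from 40000 nM to 250000 nM.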

Compound 4, half-maximal cytotoxic concentration: > 400000 nM
Compound 4 was reported as a limit; the forecaster's own chance of this, stated with the estimate: 15%; middle value at least 4.0-fold (0.60 log units) from the limit.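

In this assay, the change from phenyl to 4-fluorophenyl gave an at least 3.2-fold higher number from compound 3 to compound 4 (0.51 log units; beyond the scatter), so the step seen on the core of compound 1 did not carry over to the core of compound 3 in size or direction: the same change on two cores in this assay, a 1.5-fold lower number (0.16 log units; within the scatter) from compound 1 to compound 2 and an at least 3.2-fold higher number (0.51 log units; beyond the scatter) from compound 3 to compound 4, at least 4.7-fold (0.67 log units) apart, beyond the scatter of two such steps

Compound 4 gives > 400000 nM, which is a limit of the assay and not a number, so this step has no upper bound and its full size stays unknown: the limit of > 400000 nM in this assay, at which 1 of the 4 values shown sits.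

The comparison rests on one pair per core, so it shows that the effect of this change depends on the core in these two cases, but it gives neither a reason for that nor a rule for any further core.

Still open, going by these compounds, is whether other groups in place of the fluoro, such as chloro, methoxy or an amine, would also behave differently on the two cores. On these data alone, it is also open whether a nitrile or a carboxylic acid in place of the nitro group would preserve the difference between the two cores.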